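Putting the Benzyl Group Back on Compound 2

This account rests on a few compounds, and the source may have more. Where it says the series, first, only, none or still open, it means among the compounds named here.

Compound 1 `O=C(Nc1ccc(-c2cscn2)cc1)C1CCCN(Cc2ccc(F)c(F)c2)C1`: 880 nM
Compound 2 `O=C(Nc1ccc(-c2cscn2)cc1)C1CCCN(C(=O)c2ccc(F)c(F)c2)C1`: > 20000 nM (a limit)
Compound 3 `O=C(Nc1ccc2scnc2c1)C1CCCN(Cc2ccc(F)c(F)c2)C1`: > 20000 nM (a limit)

In a functional assay on A-375 cells (Homo sapiens) for antiproliferative activity (on this read-out lower numbers stand for stronger inhibition and higher numbers for weaker inhibition), compound 2 gives > 20000 nM, which is a limit of the assay and not a number. Compound 2 therefore stands at the limit of > 20000 nM in this assay, at which 2 of the 3 values shown sit.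

Compound 4 `O=C(Nc1ccc(-c2cscn2)cc1)C1CCCN(Cc2ccccc2F)C1` changes one place in compound 2: 2-fluorobenzyl in place of (3,4-difluorophenyl)carbonyl on an amine nitrogen in a ring. In words, 2-fluorobenzyl comes in place of (3,4-difluorophenyl)carbonyl on an amine nitrogen in a ring.

Among the measured compounds shown here, one measured step bears on this change: an at least 22-fold higher number from compound 1 to compound 2 (1.35 log units; beyond the scatter). That step is large and beyond the scatter, and it put (3,4-difluorophenyl)carbonyl in place of 3,4-difluorobenzyl at the same spot. For the measured compounds named here, the change to compound 4 runs the opposite way, but it brings 2-fluorobenzyl rather than 3,4-difluorobenzyl, and no measured compound shows what that difference does. A large step to a lower number is therefore expected in this assay, towards compound 1 at 880 nM. The expected step is an at least 13-fold lower number from compound 2 to compound 4 (1.12 log units; beyond the scatter). For compound 4 the estimate is 1500 nM, with an expected range of 400 nM to 8000 nM.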

Compound 4, half-maximal inhibitory concentration: 4000 nM
Compound 4: middle estimate off by 2.7-fold (0.43 log units), on the low side; the range from low to high includes it.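

In this assay, 2-fluorobenzyl in place of (3,4-difluorophenyl)carbonyl gives an at least 5.0-fold lower number from compound 2 to compound 4 (0.69 log units; beyond the scatter), so on this amine nitrogen in a ring, a second benzyl group besides the 3,4-difluorobenzyl of compound 1 also gives a measurable value. That step size is only a minimum because compound 2 sits at a limit of the assay, not at a number: the limit of > 20000 nM in this assay, at which 2 of the 4 values shown sit. The benzyl group alone does not settle the value, however, since the fluorine pattern on its ring also matters: the change from 3,4-difluorophenyl to 2-fluorophenyl gives a 4.5-fold higher number from compound 1 to compound 4 (0.66 log units; beyond the scatter).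

That change alters both the number and the places of the fluorines, and the compounds shown cannot separate the two. On these data alone, whether an unsubstituted benzyl or a 4-fluorobenzyl group on the same nitrogen would fall nearer compound 1 or compound 4 remains open.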